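Methyl on the phenol oxygen: from compound 2 to compound 4

This account rests on a few compounds, and the source may have more. Where it says the series, first, only, none or still open, it means among the compounds named here.

Measured so far:
compound 1 `O=C(Nc1cccc(-n2cc(-c3ccncc3)c(-c3cc(O)cc(Cl)c3)n2)c1)Nc1ccc(Cl)c(C(F)(F)F)c1` — 1960 nM
compound 2 `O=C(Nc1cccc(-n2cc(-c3ccncc3)c(-c3cc(O)cc(Cl)c3)n2)c1)Nc1ccc(Cl)c(Cl)c1` — 1740 nM
compound 3 `COc1cc(Cl)cc(-c2nn(-c3cccc(NC(=O)Nc4cc(C(F)(F)F)cc(C(F)(F)F)c4)c3)cc2-c2ccncc2)c1` — 330 nM

All three values come from a functional assay on HCT-116 cells (Homo sapiens) for inhibition, read by sulforhodamine B assay, with a stated time of 48 h; on this read-out higher numbers stand for weaker inhibition and lower numbers for stronger inhibition. Compound 2 stands second highest of the three; its nearest neighbour is compound 1, whose value lies within the scatter, while compound 3 is well below it. Compound 4 `COc1cc(Cl)cc(-c2nn(-c3cccc(NC(=O)Nc4ccc(Cl)c(Cl)c4)c3)cc2-c2ccncc2)c1` differs from compound 2 by methyl in place of hydrogen on an oxygen on an aromatic ring, which is hydroxy to methoxy, so 3-chloro-5-hydroxyphenyl becomes 3-chloro-5-methoxyphenyl. For the measured compounds named here, no measured pair isolates this change. Going by the values given here, the only measured step, a 1.1-fold lower number from compound 1 to compound 2 (0.05 log units; within the scatter), concerns a different site. Compound 3 carries methoxy yet also differs at the other end, so its lower value cannot be credited to the oxygen. Expectation for this assay is therefore cautious: compound 4 is estimated at 1100 nM (350 nM to 3500 nM), a step of a 1.6-fold lower number from compound 2 to compound 4 (0.20 log units; within the scatter) expected.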

Compound 4, half-maximal inhibitory concentration: 2020 nM
Compound 4: middle estimate off by 1.8-fold (0.26 log units), on the low side, within the range that was stated.
By their numbers in this assay, from the lowest: compound 3; then compounds 2, 1 and 4 (each within the scatter of the next).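

For the compounds shown here, replacing hydroxy with methoxy, the only change in this pair, gives a 1.2-fold higher number from compound 2 to compound 4 (0.06 log units; within the scatter) in this assay and so isolates this swap for the first time. With the hydrogen on that oxygen replaced by methyl, the number stays within the scatter, so this pair gives no sign that the hydrogen matters for inhibition in these cells. No measurement at hand explains this result. Still open, from the compounds shown here alone, is whether an ethyl group or a longer chain on that oxygen, or an amine in its place, would behave the same way. Also open, going by these compounds, is whether the same swap would stay as quiet with different groups at the far end of the molecule.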